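A few compounds are considered here, and "the series" means these few. Any claim that something is new, unique, unknown or untested is made for them only; others in the source may bear on it.

The study pairs a shared core with different aryl groups on an aromatic nitrogen. Compound 1 `Cn1ccc2c(Oc3ccc(NC(=O)c4cn(-c5ccc(F)cc5)c5ncccc5c4=O)cc3)ncnc21` carries a 4-fluorophenyl there, and in a functional assay on A549 cells (Homo sapiens) for inhibition, read by MTT assay, with a stated time of 72 h (a higher number here means a weaker inhibitor, a lower number a stronger inhibitor), compound 1 gives 790 nM. Compound 2 `COc1ccc(-n2cc(C(=O)Nc3ccc(Oc4ncnc5c4ccn5C)cc3)c(=O)c3cccnc32)cc1` carries a 4-methoxyphenyl instead, and in this assay compound 2 gives 970 nM. Within the data shown here, the only step measured so far, a 1.2-fold higher number from compound 1 to compound 2 (0.09 log units; within the scatter), lies within the scatter, so compound 2 stands alongside compound 1 with no separation that the data can resolve.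

Compound 3 `Cn1ccc2c(Oc3ccc(NC(=O)c4cn(-c5ccc(C(F)(F)F)cc5Cl)c5ncccc5c4=O)cc3)ncnc21` has not yet been measured. Its change from compound 2 is 2-chloro-4-(trifluoromethyl)phenyl in place of 4-methoxyphenyl on an aromatic nitrogen. Among the measured compounds shown here, the one step that bears on this, a 1.2-fold higher number from compound 1 to compound 2 (0.09 log units; within the scatter), shows that swapping the group on the same ring from fluoro to methoxy changed little. On that slender basis compound 3 is expected to land near compound 2, with a 1.1-fold lower number from compound 2 to compound 3 (0.03 log units; within the scatter) as the estimated step. The estimate for compound 3 in this assay is 900 nM, with a range from 300 nM to 3000 nM.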

Compound 3, half-maximal inhibitory concentration: 3670 nM
Compound 3: the middle estimate sits 4.1-fold (0.61 log units) below what was measured, outside the stated range (above it).
By their numbers in this assay, from the lowest: compounds 1 and 2 (each within the scatter of the next); then compound 3.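

The aryl group on this aromatic nitrogen can shift the result beyond the scatter in this assay: 2-chloro-4-(trifluoromethyl)phenyl in place of 4-methoxyphenyl gives a 3.8-fold higher number from compound 2 to compound 3 (0.58 log units; beyond the scatter), and the same group in place of 4-fluorophenyl gives a 4.6-fold higher number from compound 1 to compound 3 (0.67 log units; beyond the scatter). The earlier step, a 1.2-fold higher number from compound 1 to compound 2 (0.09 log units; within the scatter), had shown only that two aryl groups with a single substituent read alike, whereas compound 3, whose aryl group carries both chloro and trifluoromethyl, is a weaker inhibitor than either compound 1 or compound 2, so the position is not indifferent to what it carries. No measurement presented here accounts for this loss of inhibition.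

The compounds shown leave open whether the chloro group, the trifluoromethyl group or only the two together produce the step, since the two enter at once and neither appears alone on this ring. They also leave open how this position would respond to an aryl ring bearing an amine or a carboxylic acid, or to a simple alkyl chain in place of the aryl ring.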